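This account rests on a few compounds, and the source may have more. Where it says the series, first, only, none or still open, it means among the compounds named here.

Compound 1 (`CN1CCN(c2ccc(S(=O)(=O)Oc3cccc(I)c3)cc2)C1=O`): 590 nM
Compound 2 (`COc1ccc(OS(=O)(=O)c2ccc(N3CCN(C)C3=O)cc2)cc1`): > 100000 nM (a limit)
Compound 3 (`CN1CCN(c2ccc(S(=O)(=O)Oc3ccc(F)cc3)cc2)C1=O`): > 100000 nM (a limit)

All three results come from a functional assay on HT-29 cells (Homo sapiens) for antiproliferative activity, read by sulforhodamine B assay, with a stated time of 48 h (a higher number here means a weaker inhibitor, a lower number a stronger inhibitor), and two of them are limits, not numbers. Compound 3 reports only a limit (> 100000 nM). Compound 2 also reports only a limit (> 100000 nM). This is the limit of > 100000 nM in this assay, at which 2 of the 3 values shown sit, and it leaves compound 3 without a number to start from.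

Compound 4 (`CN1CCN(c2ccc(S(=O)(=O)Oc3ccc(Cl)cc3)cc2)C1=O`) has chloro in place of fluoro on an aromatic carbon, para to a large group (chloro in place of fluoro on an aromatic carbon). Among the measured compounds shown here, no measured step makes this exchange. The closest is the swap at the same place (a step that the two limits leave unreadable from compound 2 to compound 3) and it gives no readable size. The two large steps (an at least 160-fold higher number from compound 1 to compound 2 (2.22 log units; beyond the scatter) and an at least 160-fold higher number from compound 1 to compound 3 (2.22 log units; beyond the scatter)) each replace the whole aryl group on an oxygen, a far bigger change than one halogen for another. A step of that size is therefore not expected here. In this assay only a modest shift is expected, towards a lower number if there is any, and compound 4 may well report a limit too. The expected step is an at least 2.5-fold lower number from compound 3 to compound 4 (0.39 log units; beyond the scatter) and it remains an estimate. Compound 4 is estimated at 40000 nM (expected range 5000 nM to 100000 nM).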

Compound 4, half-maximal inhibitory concentration: 12000 nM
Compound 4: the middle estimate sits 3.3-fold (0.52 log units) above what was measured; the range from low to high includes it.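

In this assay, among the compounds shown here, chloro in place of fluoro on an aromatic carbon, para to a large group, gives the first readable step at this place, an at least 8.3-fold lower number from compound 3 to compound 4 (0.92 log units; beyond the scatter), so a single halogen exchange here is enough to bring a number out of the limit. Chloro also stands apart from methoxy at the same place, with an at least 8.3-fold lower number from compound 2 to compound 4 (0.92 log units; beyond the scatter), whereas the step between compound 2 and compound 3 cannot be read. Even so, the 4-chlorophenyl group does not reach the 3-iodophenyl group, with a 20-fold higher number from compound 1 to compound 4 (1.31 log units; beyond the scatter), so this exchange closes only part of the distance to compound 1.

Going by these compounds, the true size of the two steps to compound 4 stays open, because compound 2 and compound 3 give no number to measure from: the limit of > 100000 nM in this assay, at which 2 of the 4 values shown sit. Also open is whether a 4-bromophenyl or 4-iodophenyl group would lower the number further, and whether a 3-chlorophenyl group would come close to compound 1, which would separate the effect of the halogen from that of its place on the ring.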